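The source may hold more compounds than are shown below. What is called first, only, known or untested is meant among the compounds shown, and "the series" means these compounds.

Series notes. For the measured compounds named here, compound 1 `C[C@]1(O)CC(=O)OC(CSc2nc(-c3ccccc3)c(-c3ccccc3)[nH]2)C1` is one of two compounds measured so far in an assay on microsomes from liver for inhibition of sterol O-acyltransferase 1 (Rattus norvegicus); a higher number here means a weaker inhibitor, a lower number a stronger inhibitor. In this assay compound 1 gives 140 nM, the lower of the two numbers. Compound 2 `C[C@@]1(O)CC(=O)OC(CSc2nc(-c3ccc(Cl)cc3)c(-c3ccc(Cl)cc3)[nH]2)C1` is the nearest: in this assay compound 2 gives 180 nM, and the gap to compound 1 lies within the scatter, so the two values show no order between them. Compound 3 `c1ccc(CSc2nc(-c3ccccc3)c(-c3ccccc3)[nH]2)cc1` has not been measured. Against compound 1 it differs in one place: a group of 6 heavy atoms (6 carbon; one six-membered aromatic ring of carbon only) in place of a group of 9 heavy atoms (6 carbon, 3 oxygen; one six-membered non-aromatic ring with 1 hetero atom), on a saturated chain carbon bound to a sulfur. The hydrogen-bond donor and the acceptors of the leaving group are lost. Neither measured compound speaks to this change, since compound 1 and compound 2 differ only elsewhere, so the expectation rests on the size of the change alone. A modest weakening beyond the scatter is expected, a 2.5-fold higher number from compound 1 to compound 3 (0.40 log units; beyond the scatter). Compound 3 is estimated at 350 nM, expected between 90 nM and 1400 nM.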

Compound 3, half-maximal inhibitory concentration: 290 nM
Compound 3: middle estimate off by 1.2-fold (0.08 log units), on the high side, within the range that was stated.
By their numbers in this assay, from the lowest: compounds 1, 2 and 3 (each within the scatter of the next, the first and the last beyond it).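

In this assay this position proves tolerant: the change on the saturated chain carbon bound to a sulfur amounts to a 2.1-fold higher number from compound 1 to compound 3 (0.32 log units; beyond the scatter) and remains modest. Compound 3 still gives 290 nM with phenyl in place, so neither the six-membered non-aromatic ring nor its 1 hydrogen-bond donor and 3 hydrogen-bond acceptors are required for inhibition at this level, although the exchange does cost a step beyond the scatter. Nothing at hand accounts for the size of this step.

A single exchange cannot separate the contributions of the hydroxyl, the carbonyl and the ring itself, and an amine, a carboxylic acid or a longer chain on the same carbon would test this position further. From the compounds shown here alone, it also remains open whether phenyl in this place gives a similar step on the core of compound 2.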